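This account rests on a few compounds, and the source may have more. Where it says the series, first, only, none or still open, it means among the compounds named here.

Working notes on the series, read in a functional assay on HepG2 cells (Homo sapiens) for antiproliferative activity, read by MTT assay, with a stated time of 24 h; a higher number here means a weaker inhibitor, a lower number a stronger inhibitor. Compound 1 `COc1cccc(CSc2nnc(-c3ccc4c(c3)OCCO4)n2-c2ccccc2)c1` gives 35100 nM, and compound 2 `Cc1ccc(CSc2nnc(-c3ccc4c(c3)OCCO4)n2-c2ccccc2)cc1` gives 56800 nM. Within the data shown here, these are the only two numbers so far and they lie within the scatter of each other, so compound 2 stands level with compound 1 and no order can be drawn between them.

Compound 3 `Fc1ccccc1CSc1nnc(-c2ccc3c(c2)OCCO3)n1-c1ccccc1` keeps the shared core and differs from compound 2 only on a saturated chain carbon bound to a sulfur, where 2-fluorophenyl stands in place of 4-methylphenyl: 2-fluorophenyl in place of 4-methylphenyl on a saturated chain carbon bound to a sulfur.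

Among the measured compounds shown here, the only measured step at this place is a 1.6-fold higher number from compound 1 to compound 2 (0.21 log units; within the scatter), and it stays within the scatter. For the measured compounds named here, no measured compound carries 2-fluorophenyl, so the data give no direct reading of that group, and a single step is thin support. On that evidence, no change beyond the scatter is expected in this assay. The expected size of the move is a 1.4-fold lower number from compound 2 to compound 3 (0.13 log units; within the scatter). For compound 3 the estimated value is 42000 nM, with an expected range from 18000 nM to 95000 nM.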

Compound 3, half-maximal inhibitory concentration: 810 nM
For compound 3 the middle estimate is 52-fold (1.71 log units) above the measured one; measured number below the stated range.
By their numbers in this assay, from the lowest: compound 3; then compounds 1 and 2 (each within the scatter of the next).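

In this assay the place on a saturated chain carbon bound to a sulfur proves far from indifferent: 2-fluorophenyl in place of 4-methylphenyl gives a large move (a 70-fold lower number from compound 2 to compound 3 (1.85 log units; beyond the scatter)), and 2-fluorophenyl in place of 3-methoxyphenyl gives another (a 43-fold lower number from compound 1 to compound 3 (1.64 log units; beyond the scatter)). Among these compounds, the one earlier step here stayed within the scatter, so compounds 1 and 2 gave no sign that this place could move the reading at all. Compound 3 now stands apart from both, although 4-methylphenyl and 2-fluorophenyl have the same count of heavy atoms and the same count of hydrogen-bond donors and acceptors, so those counts do not separate the two groups.

No measurement at hand accounts for the size of these steps.

As far as these compounds go, with a single fluorinated group in the set, it remains open whether the move belongs to the fluorine or to its printed 2-position on the ring, and how plain benzyl, 4-fluorobenzyl or 2-chlorobenzyl would read at this place. Also open, from the compounds shown here alone, is whether a group carrying an amine or a carboxylic acid would be tolerated here, and whether the phenyl on the shared core can be changed without losing the reading of compound 3.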